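Notes on adding a chloro to compound 3

The compounds below may be only part of what the source reports. "The series", "measured", "known", "first", "only" and "open" are said of these compounds alone.

Measured in a functional assay on K562 cells (Homo sapiens) for cytotoxicity, read by MTT assay, with a stated time of 24 h; on this read-out lower numbers stand for stronger inhibition and higher numbers for weaker inhibition:
- compound 1 (`CN1C/C(=C\c2cccc([N+](=O)[O-])c2)C(=O)/C(=C/c2ccccc2F)C1`) gives 3890 nM
- compound 2 (`COc1cc(/C=C2\CN(C)C/C(=C\c3ccc(C#N)cc3)C2=O)cc(OC)c1OC`) gives 4290 nM
- compound 3 (`CN1C/C(=C\c2ccc(Cl)cc2)C(=O)/C(=C/c2cccc([N+](=O)[O-])c2)C1`) gives > 20000 nM as a limit and not a number

Compound 3 gives only a limit (the limit of > 20000 nM in this assay, at which 1 of the 3 values shown sits) and no number. The change to compound 4 (`CN1C/C(=C\c2cccc([N+](=O)[O-])c2)C(=O)/C(=C/c2ccc(Cl)cc2Cl)C1`) is chloro in place of hydrogen on an aromatic carbon and turns 4-chlorophenyl into 2,4-dichlorophenyl, with the new chloro ortho to a large group and meta to a chloro group. For the measured compounds named here, the one measured step that bears on this is an at least 5.1-fold higher number from compound 1 to compound 3 (0.71 log units; beyond the scatter) with 4-chlorophenyl in place of 2-fluorophenyl. Going by the values given here, no measured step involves compound 2. The fluoro of compound 1 is likewise ortho to a large group, so a step toward lower numbers in this assay is expected, of similar or smaller size than an at least 5.1-fold higher number from compound 1 to compound 3 (0.71 log units; beyond the scatter) and resting on that single step. A result at the limit again remains possible. For compound 4 an estimated 8000 nM is expected, with 2500 nM to 20000 nM as the expected range. This estimate means an at least 2.5-fold lower number from compound 3 to compound 4 (0.39 log units; beyond the scatter) as the expected step.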

Compound 4, half-maximal inhibitory concentration: 12400 nM
Compound 4: middle estimate off by 1.6-fold (0.19 log units), on the low side; the measured number falls inside the stated range.
By their numbers in this assay, from the lowest: compounds 1 and 2 (each within the scatter of the next); then compound 4. At a limit, above all of these: compound 3.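

In this assay chloro in place of hydrogen on the aromatic carbon ortho to a large group gives an at least 1.6-fold lower number from compound 3 to compound 4 (0.20 log units; that floor lies within the scatter) and so turns a limit into a number, although the floor of that step does not clear the scatter. On these data alone, compound 3 stands only at a limit, so the true size of this step stays unknown: the limit of > 20000 nM in this assay, at which 1 of the 4 values shown sits. With 2,4-dichlorophenyl in place of 2-fluorophenyl, the series now has a 3.2-fold higher number from compound 1 to compound 4 (0.50 log units; beyond the scatter) as a step of known size at this position, where the step to compound 3 gave only a floor.

As far as these compounds go, what an amine or a carboxylic acid on the same aromatic carbon would give in this assay stays open. Also open, from the compounds shown here alone, is whether 2-chlorophenyl, without the chloro of the 4-chlorophenyl, would give a number closer to that of compound 1 or to that of compound 4.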